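The compounds below may be only part of what the source reports. "The series", "measured", "known", "first", "only" and "open" are said of these compounds alone.

Measured in an ADME assay on Vero cells (Chlorocebus sabaeus) for cytotoxicity, read by resazurin assay, with a stated time of 3 days; on this read-out higher numbers stand for lower toxicity in this test and lower numbers for higher toxicity in this test:
- compound 1 `COc1ccc(Nc2nc(N)nc(CSc3nnc(-c4ccccc4)n3-c3ccccc3)n2)cc1`: "not determined" (no result reported)
- compound 2 `Cc1ccccc1Nc1nc(N)nc(CSc2nnc(-c3ccccc3)n2-c2ccccc2)n1`: 1750 ug/mL
- compound 3 `COc1ccc(Nc2nc(N)nc(CSc3nnc(-c4ccccc4)n3/N=C/c3ccccc3)n2)cc1`: 1500 ug/mL

Only two of these compounds have a number, so the comparison is narrow. Compound 3 gives 1500 ug/mL, which lies within the scatter of compound 2 at 1750 ug/mL. Compound 4 `Cc1ccccc1Nc1nc(N)nc(CSc2nnc(-c3ccccc3)n2/N=C/c2ccccc2)n1` has 2-methylphenyl in place of 4-methoxyphenyl on a nitrogen on an aromatic ring. Among the compounds with values here, no measured pair shows this change alone. However, compound 2, which already carries 2-methylphenyl, gives 1750 ug/mL, so no change beyond the scatter is expected in this assay. The estimated step of a 1.1-fold higher number from compound 3 to compound 4 (0.03 log units; within the scatter) has no firm direction. For compound 4 the expected value is 1600 ug/mL, with an estimated range from 800 ug/mL to 3000 ug/mL.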

Compound 4, half-maximal cytotoxic concentration: 1250 ug/mL
The estimate for compound 4 lay 1.3-fold (0.11 log units) above the measured number, within the range that was stated.
By their numbers in this assay, from the lowest: compounds 4, 3 and 2 (each within the scatter of the next).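

In this assay, 2-methylphenyl in place of 4-methoxyphenyl on a nitrogen on an aromatic ring now has a measured pair of its own (a 1.2-fold lower number from compound 3 to compound 4 (0.08 log units; within the scatter)), and the change leaves the number within the scatter. The other place of difference also gains a pair, with a group of 8 heavy atoms in place of a group of 6 heavy atoms on an aromatic nitrogen (a 1.4-fold lower number from compound 2 to compound 4 (0.15 log units; within the scatter)), again within the scatter. Nothing available explains these results. From the compounds shown here alone, whether an amine or a carboxylic acid on that nitrogen would move the number beyond the scatter stays open.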